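Phenyl for acetyl in a level trio

A few compounds are considered here, and "the series" means these few. Any claim that something is new, unique, unknown or untested is made for them only; others in the source may bear on it.

Measured so far in a physicochemical assay for lipophilicity, read by HPLC, measured as chromatographic lipophilicity, at pH 7.4; on this read-out lower numbers stand for lower lipophilicity and higher numbers for higher lipophilicity
compound 1 `CC(=O)N1CCC(C(=O)N2N=CCC2c2ccccc2)CC1` gives 2.5
compound 2 `CC(C)(C)C(=O)N1CCNCC1c1ccccc1` gives 2.5
compound 3 `CC(=O)N1CCC(C(=O)N2N=CC[C@H]2c2ccccc2)CC1` gives 2.5

Compound 1 stands level with compound 2 and compound 3 at these digits, so none of the three sets itself apart. The next compound to be measured is compound 4 (`O=C(C1CCN(c2ccccc2)CC1)N1N=CCC1c1ccccc1`), which keeps the core of compound 1 and changes one group. The change is phenyl in place of acetyl on an amine nitrogen in a ring.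

For the measured compounds named here, only one measured step is available as a yardstick. That step, no change at the digits printed from compound 1 to compound 3 (within the scatter), concerns only the fact that one of compounds 1 and 3 is drawn with a defined configuration and the other without, at the place where they differ and leaves the acetyl in place, so it gives no size for this swap. The expectation must therefore rest on the structural change itself. Compound 1 at 2.5 loses a group that holds a hydrogen-bond acceptor and gains a larger ring of carbon only, and this is expected to raise the number well beyond the scatter. The expected size is a number 1.70 log units higher from compound 1 to compound 4 (beyond the scatter) in this estimate. In this assay compound 4 is estimated at 4.2 with an expected range from 3.6 to 4.8 as the likely span.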

Compound 4, distribution coefficient: 6.3
Compound 4: middle estimate off by 2.10 log units, on the low side; the whole stated range lies below it.
By their numbers in this assay, from the lowest: compounds 1, 2 and 3 (each within the scatter of the next); then compound 4.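

In this assay, for the compounds shown here, the swap of phenyl in place of acetyl on an amine nitrogen in a ring gives a number 3.80 log units higher from compound 1 to compound 4 (beyond the scatter) and so shows that this place on the core of compound 1 can move the number by a large amount, something the level trio could not reveal, since its only step, no change at the digits printed from compound 1 to compound 3 (within the scatter), left the acetyl in place. The swap takes away the acetyl with its hydrogen-bond acceptor and brings in a six-membered aromatic ring of carbon only, and the two differences arrive together, so the size belongs to the whole change and not to either part alone. Nothing measured here bears on why the number climbs so far.

The compounds shown leave open how much of the rise goes with losing the acetyl and how much with gaining the phenyl, and a methyl or a cyclohexyl on the same nitrogen would help to separate the two. They also leave open whether a phenyl carrying a carboxylic acid or an amine would keep the number near that of compound 4 or bring it back towards that of compound 1.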